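Sulfonamide series notes: step from compound 2 to compound 4

The compounds below may be only part of what the source reports. "The series", "measured", "known", "first", "only" and "open" are said of these compounds alone.

Measured compounds:
compound 1 `CCCC(=O)N(Cc1ccccc1)C1CCN(S(=O)(=O)c2c(C)cc(C)cc2C)CC1`: > 5000 nM
compound 2 `COC(=O)c1ccc(S(=O)(=O)N2CCC(N3CCC(C)CC3)CC2)cc1`: > 5000 nM
compound 3 `Cc1cc(C)c(S(=O)(=O)N2CCC(c3ccccc3)CC2)c(C)c1`: > 5000 nM

In a functional assay on DLD-1 cells (Homo sapiens) for antiproliferative activity, read by CellTiter-Glo, with a stated time of 72 h (on this read-out lower numbers stand for stronger inhibition and higher numbers for weaker inhibition), compound 1 gives only a limit, > 5000 nM. In this assay compound 2 likewise gives only a limit, > 5000 nM. Compound 3 also stops at a limit in this assay, > 5000 nM. Compound 2 therefore stands nowhere on a numerical scale; all three results sit at the limit of > 5000 nM in this assay, at which 3 of the 3 values shown sit.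

Compound 4 `CC1CCN(C2CCN(S(=O)(=O)c3ccc(-c4ccccc4F)cc3)CC2)CC1` differs from compound 2 by 2-fluorophenyl in place of methoxycarbonyl on an aromatic carbon. For the measured compounds named here, no measured step resembles this change, so its size and direction in this assay are unknown. The expectation is a step from compound 2 to compound 4 of a step that the limit leaves unreadable from compound 2 to compound 4, which cannot be resolved against a limit. Compound 4 is expected at 8000 nM, within 1500 nM to 40000 nM, most likely again reported as a limit.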

Compound 4, half-maximal inhibitory concentration: 5 nM
The estimate for compound 4 lay 1600-fold (3.20 log units) above the measured number; measured number below the stated range.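

In this assay, 2-fluorophenyl in place of methoxycarbonyl on an aromatic carbon, para to a large group, gives an at least 1000-fold lower number from compound 2 to compound 4 (3.00 log units; beyond the scatter). For the compounds shown here, this position can therefore move the read-out from a limit to a measured number, which the earlier compounds did not show. Compound 4 alone carries a number, and the others stop at a limit: the limit of > 5000 nM in this assay, at which 3 of the 4 values shown sit.

Open, going by these compounds, is whether the ring alone accounts for the step or the fluorine contributes, which an unsubstituted phenyl at this position would separate. On these data alone, how an amine or a pyridine there would compare also remains open.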